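This account rests on a few compounds, and the source may have more. Where it says the series, first, only, none or still open, it means among the compounds named here.

In a functional assay on K562 cells (Homo sapiens) for antiproliferative activity, read by MTT assay, with a stated time of 48 h (a higher number here means a weaker inhibitor, a lower number a stronger inhibitor), compound 2 (`Cn1cc(C2=C(c3nn(CCCN4CCCCC4)c4ncccc34)C(=O)N(c3cccc4ccccc34)C2=O)c2ccccc21`) gives 3180 nM and so holds the lower of the two true numbers in this small set. Compound 1 (`Cn1cc(C2=C(c3nn(CCn4ccnc4)c4ncccc34)C(=O)N(c3ccccc3)C2=O)c2ccccc21`) gives 26400 nM in the same test, a clearly higher number. Compound 3 (`Cn1cc(C2=C(c3nn(CCn4ccnc4)c4ncccc34)C(=O)NC2=O)c2ccccc21`) gives only a limit of the assay (> 100000 nM) and not a true number.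

Compound 4 (`COc1ccc(N2C(=O)C(c3cn(C)c4ccccc34)=C(c3nn(CCCN4CCCCC4)c4ncccc34)C2=O)cc1`) has not yet been measured. It changes compound 2 in one place (4-methoxyphenyl in place of naphthalen-1-yl on an amide-type nitrogen in a ring): 4-methoxyphenyl stands in place of naphthalen-1-yl on an amide-type nitrogen in a ring.

Within the data shown here, no measured step compares these two groups directly. Among the measured compounds shown here, the only step at this nitrogen is an at least 3.7-fold higher number from compound 1 to compound 3 (0.57 log units; beyond the scatter) and it puts hydrogen in place of phenyl. In that pair, losing the aromatic group goes with a higher number. Compound 4 keeps an aromatic ring on the nitrogen, so a loss on that scale is not expected, although one ring replaces two.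

The expected result in this assay is a 1.9-fold higher number from compound 2 to compound 4 (0.28 log units; within the scatter) as a small rise in the number that may not clear the usual scatter. For compound 4 the estimate is 6000 nM with an expected range from 1800 nM to 20000 nM for the measurement.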

Compound 4, half-maximal inhibitory concentration: > 100000 nM
Compound 4 was reported as a limit; the forecaster's own chance of this, stated with the estimate: 5%; middle value at least 16-fold (1.22 log units) away from the limit.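

In this assay, replacing naphthalen-1-yl with 4-methoxyphenyl on the amide-type nitrogen gives an at least 31-fold higher number from compound 2 to compound 4 (1.49 log units; beyond the scatter), so keeping one aromatic ring at this position is not enough to retain the activity of compound 2. The earlier step at this nitrogen, an at least 3.7-fold higher number from compound 1 to compound 3 (0.57 log units; beyond the scatter), only set hydrogen against phenyl, whereas this new step shows that the choice between two aromatic groups can also change the result beyond the scatter. As far as these compounds go, the reading for compound 4 is a limit of the assay and not a number, so the true size of this step remains unknown and the step gives only its smallest possible size: the limit of > 100000 nM in this assay, at which 2 of the 4 values shown sit.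

The change removes one six-membered aromatic ring and adds a methoxy group at once, so the compounds shown cannot tell which of these two differences goes with the higher number. They also leave open how naphthalen-2-yl, 4-methylphenyl or benzyl on this nitrogen, each with the side chain of compound 2, would read in this assay.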